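Swapping a Benzylamino Linker for a Thioether

This account rests on a few compounds, and the source may have more. Where it says the series, first, only, none or still open, it means among the compounds named here.

Compound 2 `Nc1cc(N)c2nc(-c3ccccc3)c(NCc3ccc(F)cc3)nc2c1` carries a (4-fluorobenzyl)amino group on an aromatic carbon of the shared core. In a functional assay on MCF7 cells (Homo sapiens) for inhibition, read by sulforhodamine B assay, with a stated time of 48 h (on this read-out higher numbers stand for weaker inhibition of growth and lower numbers for stronger inhibition of growth), compound 2 gives only a limit, < 100000 nM. Its close relative compound 1 `COc1ccc(CNc2nc3cc(N)cc(N)c3nc2-c2ccccc2)cc1OC` differs by a 3,4-dimethoxyphenyl in place of the 4-fluorophenyl on a saturated chain carbon bound to a nitrogen on an aromatic ring. In this assay compound 1 likewise gives only a limit, < 100000 nM. The step that the two limits leave unreadable from compound 1 to compound 2 therefore cannot be read, because of the limit of < 100000 nM in this assay, at which 2 of the 2 values shown sit. Compound 3 `Nc1cc(N)c2nc(-c3ccccc3)c(Sc3ccc(F)cc3)nc2c1` brings the next change: (4-fluorophenyl)sulfanyl in place of (4-fluorobenzyl)amino on an aromatic carbon. Among the measured compounds shown here, no measured step informs this change, and compound 2 itself offers no number to start from. The step that the limit leaves unreadable from compound 2 to compound 3 is expected to remain unreadable, with a real chance that compound 3 again reaches only a limit. Compound 3 is estimated at 50000 nM, within a range from 5000 nM to 200000 nM.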

Compound 3, concentration for total growth inhibition: 63100 nM
For compound 3 the middle estimate is 1.3-fold (0.10 log units) below the measured one; measured number inside the range.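

No new step can be read between compound 2 and compound 3, because compound 2 gives only a limit and not a number: the limit of < 100000 nM in this assay, at which 2 of the 3 values shown sit.

As far as these compounds go, what stays open is how far the (4-fluorophenyl)sulfanyl of compound 3 and the (4-fluorobenzyl)amino of compound 2 truly differ in this assay.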